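A chloro for nitro exchange on compound 1

A few compounds are considered here, and "the series" means these few. Any claim that something is new, unique, unknown or untested is made for them only; others in the source may bear on it.

Measured in an ADME assay on HUVEC cells (Homo sapiens) for cytotoxicity, read by MTT assay, with a stated time of 24 h; a higher number here means that more compound is tolerated, a lower number that less compound is tolerated:
compound 1 `O=[N+]([O-])c1ccccc1/C=C/c1nnc(-c2ccc3c(c2)OCCO3)o1`: 323000 nM
compound 2 `O=[N+]([O-])c1ccc(/C=C/c2nnc(-c3ccc4c(c3)OCCO4)o2)cc1`: 299000 nM
compound 3 `Fc1ccccc1/C=C/c1nnc(-c2ccc3c(c2)OCCO3)o1`: 402000 nM

Compound 1 stands among three numbers that all lie within the scatter of one another, so nothing separates it from compound 2 or compound 3. Compound 4 `Clc1ccccc1/C=C/c1nnc(-c2ccc3c(c2)OCCO3)o1` carries chloro in place of nitro on an aromatic carbon, ortho to a large group: chloro in place of nitro on an aromatic carbon. Among the compounds with values here, the data hold no measured chloro compound. Within the data shown here, one measured step bears on this change, fluoro in place of nitro on an aromatic carbon: a 1.2-fold higher number from compound 1 to compound 3 (0.10 log units; within the scatter). Resting on that small step to compound 3, no change beyond the scatter is expected in this assay. The expected step is a 1.1-fold higher number from compound 1 to compound 4 (0.03 log units; within the scatter). Compound 4 is estimated at 350000 nM, with an expected range of 220000 nM to 520000 nM.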

Compound 4, half-maximal cytotoxic concentration: 368000 nM
Estimate against measurement, compound 4: 1.1-fold (0.02 log units) below, within the range that was stated.
By their numbers in this assay, from the lowest: compounds 2, 1, 4 and 3 (each within the scatter of the next).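

In this assay, chloro at this aromatic carbon, ortho to a large group, stays level with nitro (a 1.1-fold higher number from compound 1 to compound 4 (0.06 log units; within the scatter)) and with fluoro (a 1.1-fold lower number from compound 3 to compound 4 (0.04 log units; within the scatter)). The three groups tried at this place are therefore not separated, and a single exchange no longer carries that reading. Nothing available here accounts for this. On these data alone, whether an amine or a carboxylic acid at this carbon would move the number beyond the scatter stays open. So does whether chloro would behave alike at the place nitro holds in compound 2.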